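Oxolan-3-yl for oxetan-3-yl on a weak compound

The source may report more compounds than this note shows. Statements on the series, on what has been measured and on what is new or still open speak of the compounds shown alone.

In a functional assay on HT-29 cells (Homo sapiens) for inhibition, read by luminescence and CellTiter-Glo, with a stated time of 24 h (on this read-out higher numbers stand for an effect only at larger amounts of compound and lower numbers for an effect already at smaller amounts), compound 2 `CN1C(=S)[C@@H](NC(=O)c2nc(Cc3ccccc3)n(CC3COC3)n2)COc2ccccc21` stands highest of the two measured compounds at 2830 nM, while compound 1 `CN1C(=S)[C@@H](NC(=O)c2nc(Cc3ccccc3)n(C)n2)COc2ccccc21` gives 2.5 nM. Compound 3 `CN1C(=S)[C@@H](NC(=O)c2nc(Cc3ccccc3)n(CC3CCOC3)n2)COc2ccccc21` differs from compound 2 as follows: oxolan-3-yl in place of oxetan-3-yl on a saturated chain carbon bound to an aromatic nitrogen. In words, oxolan-3-yl stands in place of oxetan-3-yl on a saturated chain carbon bound to an aromatic nitrogen. Within the data shown here, only one measured step bears on this, the large 1100-fold higher number from compound 1 to compound 2 (3.05 log units; beyond the scatter), where oxetan-3-yl replaced hydrogen at that place. Compound 3 keeps a ring there, so nothing beyond the scatter is expected, in either direction. For compound 3 the expected step is a 1.1-fold higher number from compound 2 to compound 3 (0.03 log units; within the scatter). The estimate for compound 3 is 3000 nM, with an expected range of 700 nM to 12000 nM.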

Compound 3, half-maximal effective concentration: 4420 nM
Estimate against measurement, compound 3: 1.5-fold (0.17 log units) below, within the range that was stated.
By their numbers in this assay, from the lowest: compound 1; then compounds 2 and 3 (each within the scatter of the next).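

In this assay the two rings cannot be told apart, with a 1.6-fold higher number from compound 2 to compound 3 (0.19 log units; within the scatter) and no order between them. The high number at this place is therefore not confined to oxetan-3-yl: compound 1, with no ring there, still differs with a 1800-fold higher number from compound 1 to compound 3 (3.25 log units; beyond the scatter) from the oxolan-3-yl compound. Nothing measured here accounts for this gap. The compounds shown leave open whether any ring at this place keeps the high number, as a piperidine would test, and whether an open chain such as methoxyethyl or a carboxylic acid would come closer to compound 1.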